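A few compounds are considered here, and "the series" means these few. Any claim that something is new, unique, unknown or untested is made for them only; others in the source may bear on it.

Compound 2, with the structure `COc1cccc(NC(=O)c2c(O)c3cccnc3n(-c3ccccc3)c2=O)c1`, gives 5.7% in a functional assay on the whole organism for inhibition, with Rattus norvegicus as the target, read by paw edema, at a dose of 100 mg/kg by the oral route (on this read-out lower numbers stand for less inhibition and higher numbers for more inhibition at the one dose given (going by the name of the read-out)), the higher of the two numbers at hand; compound 1, with the structure `O=C(Nc1ccccn1)c1c(O)c2cccnc2n(-c2ccccc2)c1=O`, gives -13.5% in this assay. Within the data shown here, the one measured step, a number 19.2 percentage points higher from compound 1 to compound 2 (beyond the scatter), is the only guide available. Compound 3, with the structure `Cc1ccccc1NC(=O)c1c(O)c2cccnc2n(-c2ccccc2)c1=O`, differs from compound 2 in that (2-methylphenyl in place of 3-methoxyphenyl on an amide-type nitrogen). The measured step also changes the group on the amide-type nitrogen, but it exchanges pyridin-2-yl for 3-methoxyphenyl, whereas here one carbon-only aromatic ring replaces another. Among the measured compounds shown here, that step, modest in size, therefore bears on the present change only loosely, and no step is measured between two such rings. The expectation is a step of a number 2.7 percentage points lower from compound 2 to compound 3 (within the scatter), no larger than the scatter in either direction. Compound 3 is accordingly estimated at 3%, with a range from -15% to 20%.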

Compound 3, a percentage reported as inhibition, in the whole organism at one dose (the size of the read-out at that dose, not a potency): 11.7%
Compound 3: middle estimate off by 8.7 percentage points, on the low side; the measured number falls inside the stated range.
By their numbers in this assay, from the lowest: compound 1; then compounds 2 and 3 (each within the scatter of the next).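

In this assay, replacing one carbon-only aromatic ring with another on the amide-type nitrogen gives a number 6 percentage points higher from compound 2 to compound 3 (within the scatter), so 3-methoxyphenyl and 2-methylphenyl cannot be told apart here, even though the hydrogen-bond acceptor of the leaving group is gone. The step of a number 25.2 percentage points higher from compound 1 to compound 3 (beyond the scatter) shows that a second carbon-only ring also stands clear of pyridin-2-yl, so the gap seen with compound 2 is not confined to the 3-methoxyphenyl group. No information is at hand that accounts for these numbers.

Still open, as far as these compounds go, is whether an amine or a carboxylic acid on the phenyl ring would move the number beyond the scatter from that of compound 3. From the compounds shown here alone, it is also open how a saturated ring such as cyclohexyl on the same nitrogen would compare.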